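The source may report more compounds than this note shows. Statements on the series, on what has been measured and on what is new or still open speak of the compounds shown alone.

Among the compounds with values here, compound 1 `Cc1ccc(-c2csc(NC(=O)COc3ccc(Cl)c(C)c3)n2)cc1` is one of two compounds measured here. In a functional assay on A549 cells (Homo sapiens) for cytotoxicity, read by trypan blue exclusion, with a stated time of 48 h (on this read-out higher numbers stand for weaker inhibition and lower numbers for stronger inhibition), compound 1 gives 44500 nM. Its only companion, compound 2 `Cc1cc(OCC(=O)Nc2nc(-c3ccc(Br)cc3)cs2)ccc1Cl`, gives 51700 nM in this assay, and the step of a 1.2-fold higher number from compound 1 to compound 2 (0.07 log units; within the scatter) leaves the two within the scatter of each other, so compound 1 stands alongside compound 2 rather than apart from it. Compound 3 `Cc1ccc(OCC(=O)Nc2nc(-c3ccc(C)cc3)cs2)cc1` differs from compound 1 by 4-methylphenyl in place of 4-chloro-3-methylphenyl on an oxygen on a saturated carbon. Within the data shown here, no measured step touches this part of the molecule; the one known step, a bromo for a methyl on the other ring, stayed within the scatter. The expected step in this assay is therefore a 1.0-fold higher number from compound 1 to compound 3 (0.00 log units; within the scatter), none beyond the scatter. Compound 3 is estimated at 45000 nM, expected between 18000 nM and 110000 nM.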

Compound 3, half-maximal inhibitory concentration: 48800 nM
The estimate for compound 3 lay 1.1-fold (0.04 log units) below the measured number, and the stated range covers the measured number.
By their numbers in this assay, from the lowest: compounds 1, 3 and 2 (each within the scatter of the next).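

The change to 4-methylphenyl on an oxygen on a saturated carbon gives a 1.1-fold higher number from compound 1 to compound 3 (0.04 log units; within the scatter) in this assay. Within the data shown here, the earlier step touched only the other end of the molecule, so this is the first sign that the number also holds when this aromatic group loses its chlorine. No measurement here gives a reason for this result. From the compounds shown here alone, it remains open whether a group of another kind on this ring, such as an amine or a carboxylic acid, would move the number beyond the scatter.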